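The source may report more compounds than this note shows. Statements on the series, on what has been measured and on what is new or still open speak of the compounds shown alone.

Measured in a functional assay on K562 cells (Homo sapiens) for cytotoxicity, read by trypan blue exclusion, with a stated time of 96 h; on this read-out lower numbers stand for stronger inhibition and higher numbers for weaker inhibition:
- compound 1 `COC(=O)C(F)(F)Nc1cc(CS(=O)(=O)/C=C/c2c(OC)cc(OC)cc2OC)ccc1OC`: 250 nM
- compound 2 `COc1cc(OC)c(/C=C/S(=O)(=O)Cc2ccc(OC)c(NC(C)(C)C(=O)O)c2)c(OC)c1`: 7.5 nM

Compound 2 holds the lower of the two numbers. Compound 3 `COc1cc(OC)c(/C=C/S(=O)(=O)Cc2ccc(OC)c(NC(C(=O)O)c3ccc(Cl)cc3)c2)c(OC)c1` is compound 2 with carboxy(4-chlorophenyl)methyl in place of 1-carboxy-1-methylethyl on a nitrogen on an aromatic ring. Within the data shown here, the only measured step, a 33-fold lower number from compound 1 to compound 2 (1.52 log units; beyond the scatter), is large and changes the group at this same place, so the number in this assay can respond strongly here. That step does not test an added aromatic ring, however. A moderate move to a higher number is expected: a 3.3-fold higher number from compound 2 to compound 3 (0.52 log units; beyond the scatter). For compound 3 the estimated value is 25 nM, with an expected range of 6 nM to 110 nM.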

Compound 3, half-maximal inhibitory concentration: 250 nM
Compound 3: the middle estimate sits 10-fold (1.00 log units) below what was measured; measured number outside the range, above it.
By their numbers in this assay, from the lowest: compound 2; then compounds 1 and 3 (each within the scatter of the next).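

In this assay, carboxy(4-chlorophenyl)methyl on the nitrogen gives a 33-fold higher number from compound 2 to compound 3 (1.52 log units; beyond the scatter), so this position does not accept the larger group bearing a six-membered aromatic ring as it does 1-carboxy-1-methylethyl. Carboxy(4-chlorophenyl)methyl and difluoro(methoxycarbonyl)methyl differ in structure, yet the change shows no change at the digits printed from compound 1 to compound 3 (within the scatter), leaving compound 2 alone at the low end of the three. Nothing available explains this loss.

From the compounds shown here alone, whether the loss belongs to the aromatic ring or to its chlorine stays open. Also open, going by these compounds, is how a plain phenyl group, or an amine in place of the carboxylic acid, would read at this nitrogen.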